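Swapping ethynyl for iodo on two related nucleoside scaffolds

The compounds below may be only part of what the source reports. "The series", "measured", "known", "first", "only" and "open" are said of these compounds alone.

Compound 2 `C#Cc1cn([C@@H]2O[C@H](CO)[C@@H](O)[C@H]2O)c2ncnc(C)c12` and compound 1 `Cc1ncnc2c1c(I)cn2[C@@H]1O[C@H](CO)[C@@H](O)[C@H]1O` share a core and differ in one place: iodo in place of ethynyl on an aromatic carbon. In a functional assay on K562 cells (Homo sapiens), read by MTT assay, with a stated time of 72 h (on this read-out lower numbers stand for stronger inhibition and higher numbers for weaker inhibition), compound 2 gives 6920 nM, and compound 1 gives 17800 nM. The step of a 2.6-fold higher number from compound 2 to compound 1 (0.41 log units; beyond the scatter) therefore runs toward weaker inhibition. Compound 3 `C#Cc1cn([C@@H]2O[C@H](CO)[C@@H](O)[C@H]2O)c2nc(C)nc(N)c12` carries a different core; how that core differs from the core of compound 2 is not broken down here. In this assay compound 3 gives > 20000 nM, which is a limit of the assay and not a number. Compound 3 thus sits at the limit of > 20000 nM in this assay, at which 1 of the 3 values shown sits. Compound 4 `Cc1nc(N)c2c(I)cn([C@@H]3O[C@H](CO)[C@@H](O)[C@H]3O)c2n1` is related to compound 3 by the same change: iodo in place of ethynyl on an aromatic carbon. Compound 4 is expected to show the step that the limit leaves unreadable from compound 3 to compound 4. That expectation rests on the step of a 2.6-fold higher number from compound 2 to compound 1 (0.41 log units; beyond the scatter) seen with this change. Compound 4 is therefore estimated at 50000 nM, most likely reported only as a limit.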

Compound 4, half-maximal inhibitory concentration: 5120 nM
Estimate against measurement, compound 4: 9.8-fold (0.99 log units) above; the measured number lies below the stated range.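

On the core of compound 3, in this assay, putting iodo in place of ethynyl gives an at least 3.9-fold lower number from compound 3 to compound 4 (0.59 log units; beyond the scatter), so the change runs toward stronger inhibition here but toward weaker inhibition on the core of compound 2: the same change on two cores in this assay, a 2.6-fold higher number (0.41 log units; beyond the scatter) from compound 2 to compound 1 and an at least 3.9-fold lower number (0.59 log units; beyond the scatter) from compound 3 to compound 4, at least 10-fold (1.00 log units) apart, beyond the scatter of two such steps. As far as these compounds go, compound 3 gives > 20000 nM, which is a limit of the assay and not a number, so the true size of this step is unknown, though its direction is clear. Among the compounds shown here, the result shows that the effect of this change did not carry from one core to the other, but with only two cores it gives no general rule and no cause.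

The compounds shown leave open which difference between the two cores goes with the opposite steps. They also leave open how a chloro group or a longer chain, such as propynyl, would behave on that aromatic carbon of each core.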